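The source may hold more compounds than are shown below. What is called first, only, known or untested is meant among the compounds shown, and "the series" means these compounds.

Of the compounds shown here, three sharing one core have been read so far in a functional assay on SK-MEL-147 cells (Homo sapiens) for cytotoxicity, read by MTT assay, with a stated time of 24 h; on this read-out higher numbers stand for an effect only at larger amounts of compound and lower numbers for an effect already at smaller amounts. Compound 1 `CCCCC#Cc1cc(C(=O)OCC)nc2ccc(OC)cc12` gives 7200 nM, compound 2 `CCOC(=O)c1cc(C#Cc2ccc(N)cc2)c2cc(OC)ccc2n1` gives 8800 nM, and compound 3 `CCOC(=O)c1cc([Te]c2ccccc2)c2cc(OC)ccc2n1` gives 128000 nM, the highest of the three numbers and beyond the scatter from both others. Compound 4 `CCOC(=O)c1cc(C#CCCO)c2cc(OC)ccc2n1` has not yet been measured. It differs from compound 3 on an aromatic carbon, opposite the ring nitrogen: a group of 5 heavy atoms (4 carbon, 1 oxygen; no ring) in place of a group of 7 heavy atoms (6 carbon, 1 tellurium; one six-membered aromatic ring of carbon only), on an aromatic carbon. The tellurium-bearing group that leaves is the group involved in the largest step seen so far, an 18-fold higher number from compound 1 to compound 3 (1.25 log units; beyond the scatter). The other measured step, a 1.2-fold higher number from compound 1 to compound 2 (0.09 log units; within the scatter), exchanges one substituent on the triple-bonded carbon for another and stays within the scatter. The entering 4-hydroxybut-1-yn-1-yl group restores a triple bond at this place, so compound 4 is expected to fall with the two triple-bonded compounds rather than with compound 3. For the measured compounds named here, no measured compound shows what a hydroxyl-bearing chain does here, so the range is kept wide. In this assay, a large move to a lower number is expected, with the estimated change being a 14-fold lower number from compound 3 to compound 4 (1.15 log units; beyond the scatter). Compound 4 is expected near 9000 nM, with an estimated range from 3500 nM to 25000 nM.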

Compound 4, half-maximal effective concentration: > 150000 nM
Compound 4: only a limit was reported; the forecaster's own chance of this, stated with the estimate: 3%; middle value at least 16-fold (1.22 log units) away from the limit.
By their numbers in this assay, from the lowest: compounds 1 and 2 (each within the scatter of the next); then compound 3. At a limit, above all of these: compound 4.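

In this assay, compound 4 is reported only as a limit: the limit of > 150000 nM in this assay, at which 1 of the 4 values shown sits. A triple bond on this aromatic carbon, opposite the ring nitrogen, does not by itself keep the number low: butyl and 4-aminophenyl on the triple-bonded carbon stay within the scatter of each other, yet 2-hydroxyethyl in place of 4-aminophenyl gives an at least 17-fold higher number from compound 2 to compound 4 (1.23 log units; beyond the scatter), and hydroxy in place of ethyl on the saturated chain gives an at least 20-fold higher number from compound 1 to compound 4 (1.31 log units; beyond the scatter). Until now only the tellurium-bearing group had given a large step here, while this exchange on the chain also gives one, and the floor of an at least 1.1-fold higher number from compound 3 to compound 4 (0.06 log units; that floor lies within the scatter) lies within the scatter, so the 4-hydroxybut-1-yn-1-yl group and the tellurium-bearing group cannot be put in order.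

As far as these compounds go, how far the true value of compound 4 lies past its limit remains open. Also open, from the compounds shown here alone, is whether a methoxy, an amine or a carboxylic acid on that saturated chain carbon would behave like the hydroxy, and whether a longer chain carrying the hydroxy would bring the number back toward those of compound 1 and compound 2.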